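Swapping pyridin-3-yl for 1H-pyrrol-3-yl on a piperidine amide

The source may hold more compounds than are shown below. What is called first, only, known or untested is meant among the compounds shown, and "the series" means these compounds.

Measured compounds:
compound 1, `O=C(Nc1ccc(-c2cscn2)cc1)C1CCCN(Cc2ccc(F)cc2)C1`, 5000 nM
compound 2, `O=C(Nc1ccc(-c2cscn2)cc1)C1CCCN(Cc2cccc(OC(F)(F)F)c2)C1`, > 20000 nM
compound 3, `O=C(Nc1ccc(-c2cccnc2)cc1)C1CCCN(Cc2ccc(F)c(F)c2)C1`, 1060 nM

Of the compounds shown here, three share one amide core and have been tested in a functional assay on A-375 cells (Homo sapiens) for activation, with a stated time of 3 days; on this read-out higher numbers stand for an effect only at larger amounts of compound and lower numbers for an effect already at smaller amounts. Compound 1 gives 5000 nM in this assay. For compound 2 only a limit of the assay is reported, namely > 20000 nM, so no number is known for it; (the limit of > 20000 nM in this assay, at which 1 of the 3 values shown sits). Compound 3 gives 1060 nM and thereby has the lowest of the two numbers shown, its nearest neighbour being compound 1 with a higher number that lies beyond the scatter. Compound 3 and compound 1 differ in more than one place, so their two values can only be set side by side, not read as a single step.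

The unmeasured compound 4, `O=C(Nc1ccc(-c2cc[nH]c2)cc1)C1CCCN(Cc2ccc(F)c(F)c2)C1`, arises from compound 3 by one change: 1H-pyrrol-3-yl in place of pyridin-3-yl on an aromatic carbon. For the measured compounds named here, no measured pair shows this change, so the size of its effect in this assay is unknown. The expectation rests on compound 3 alone, with its value 1060 nM, and is a moderately higher number for compound 4, a step of a 2.4-fold higher number from compound 3 to compound 4 (0.37 log units; beyond the scatter), with the possibility that it stays within the scatter. Compound 4 is accordingly estimated at 2500 nM, within a range from 600 nM to 10000 nM.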

Compound 4, half-maximal effective concentration: 2610 nM
Estimate against measurement, compound 4: 1.0-fold (0.02 log units) below, and the stated range covers the measured number.
By their numbers in this assay, from the lowest: compound 3; then compounds 4 and 1 (each within the scatter of the next). At a limit, above all of these: compound 2.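

In this assay, for the compounds shown here, a 2.5-fold higher number from compound 3 to compound 4 (0.39 log units; beyond the scatter) is the first step that can be read as one change, since the earlier compounds differed from one another in more than one place. It shows that the group on an aromatic carbon of a six-membered aromatic ring of carbon only, para to a large group, does affect the read-out: the exchange of pyridin-3-yl for 1H-pyrrol-3-yl has a modest effect that lies beyond the scatter, and compound 4 still gives a number rather than a limit of the assay. The change replaces a six-membered aromatic ring bearing a hydrogen-bond acceptor with a five-membered one bearing a hydrogen-bond donor, but the evidence at hand offers no explanation for the size or direction of this step.

With ring size and the donor and acceptor counts changing together, this single step cannot show which of them matters. Going by these compounds alone, it also remains open how a phenyl ring, a carboxylic acid or an aminomethyl group would read at this position, and whether the step would hold with a benzyl group other than the one shared by compound 3 and compound 4.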